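A few compounds are considered here, and "the series" means these few. Any claim that something is new, unique, unknown or untested is made for them only; others in the source may bear on it.

Compound 1 `CCOc1ccc(-c2cccc(COc3ccc(S(=O)(=O)CC(=O)O)cc3)c2)c(Cl)c1` gives 51.3 nM in a functional assay on CHO cells for agonist activity at Free fatty acid receptor 1 (Homo sapiens), read by FLIPR and calcium flux; a lower number here means that less compound is needed, a higher number that more compound is needed for the effect. Compound 2 `COc1cc(C)c(-c2cccc(COc3ccc(S(=O)(=O)C(C)C(=O)O)cc3)c2)c(C)c1` reaches only a limit of this assay, where compound 2 gives > 1000 nM. That limit is the limit of > 1000 nM in this assay, at which 1 of the 2 values shown sits, so no number is known for compound 2, only that it lies beyond this mark. Compound 3 `COc1cc(C)c(-c2cccc(COc3ccc(S(=O)(=O)C4(C(=O)O)CC4)cc3)c2)c(C)c1` differs from compound 2 by 1-carboxycyclopropyl in place of 1-carboxyethyl on a sulfonyl sulfur. Going by the values given here, no measured pair shows this change, so the step from compound 2 is expected to be small, a step that the limit leaves unreadable from compound 2 to compound 3, likely within the scatter. Compound 3 is therefore estimated at 2000 nM, between 500 nM and 8000 nM, and may again reach only a limit.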

Compound 3, half-maximal effective concentration in the Free fatty acid receptor 1 assay: > 1000 nM
Compound 3: no number, only a limit; the forecaster's own chance of this, stated with the estimate: 60%; the middle value is on the limit's open side.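

In the Free fatty acid receptor 1 assay compound 2 gives > 1000 nM, which is a limit of the assay. In the Free fatty acid receptor 1 assay compound 3 gives > 1000 nM, which is also a limit of the assay. Compound 2 and compound 3 both reach only a limit in the Free fatty acid receptor 1 assay, so no step between them can be read: the limit of > 1000 nM in the Free fatty acid receptor 1 assay, at which 2 of the 3 values shown sit.

On these data alone, how far either compound lies beyond that limit remains open, as does whether 1-carboxycyclopropyl in place of 1-carboxyethyl makes any difference. In a physicochemical assay for lipophilicity, using the shake flask method, in phosphate buffer, measured as octanol-water partition, with a stated time of 24 h, at pH 7.4, tested at 100 uM (on this read-out lower numbers stand for lower lipophilicity and higher numbers for higher lipophilicity), compound 2 gives "not determined" (no result reported). In the physicochemical assay compound 3 gives "not determined" (no result reported).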